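The source may report more compounds than this note shows. Statements on the series, on what has been measured and on what is new or still open speak of the compounds shown alone.

Three compounds from this series have been examined in an ADME assay on HepG2 cells (Homo sapiens) for cytotoxicity, with a stated time of 48 h (a lower number here means a stronger inhibitor, a higher number a weaker inhibitor), and two of them return only a limit of the assay. Compound 1, `COc1ccc2nc(C)nc(OCC(=O)Nc3cc(C)cc(C)c3)c2c1`, shows a limit of > 100000 nM in this assay. Compound 2, `COc1ccc2c(c1)c(=O)ccn2CC(=O)Nc1cc(C)cc(C)c1`, likewise shows a limit of > 100000 nM in this assay. Among the compounds with values here, compound 3, `COc1ccc2nc(C)cc(OCC(=O)Nc3cc(C)cc(C)c3)c2c1`, is the one compound that gives a number, 20000 nM in this assay, and so it alone offers a starting point for a comparison. The other two values sit at the limit, as the limit of > 100000 nM in this assay, at which 2 of the 3 values shown sit, notes.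

Compound 4, `COc1ccc2nccc(OCC(=O)Nc3cc(C)cc(C)c3)c2c1`, has not yet been measured. It differs from compound 3 at one place: hydrogen in place of methyl on an aromatic carbon. Within the data shown here, no measured pair of compounds shows how such a change moves this assay, so the expectation for compound 4 rests on compound 3 alone. The step from compound 3 to compound 4 is expected to be small in this assay, within the scatter or slightly toward weaker inhibition, as a 1.5-fold higher number from compound 3 to compound 4 (0.18 log units; within the scatter). Compound 4 is therefore estimated at 30000 nM in this assay, in the range from 10000 nM to 100000 nM.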

Compound 4, half-maximal inhibitory concentration in the HepG2 assay: 50100 nM
Compound 4: the middle estimate sits 1.7-fold (0.22 log units) below what was measured; the measured number falls inside the stated range.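

In the HepG2 assay, hydrogen in place of methyl on an aromatic carbon next to the ring nitrogen gives a 2.5-fold higher number from compound 3 to compound 4 (0.40 log units; beyond the scatter), so this position is not silent in the cytotoxicity read-out, which compound 3 alone could not show. The step is modest, and it points toward weaker inhibition. In a physicochemical assay for solubility, read by chemiluminescence, measured as kinetic solubility (a higher number here means a more soluble compound, a lower number a less soluble compound), compound 3 gives 26000 nM and compound 4 gives 51000 nM, which is a 2.0-fold higher number from compound 3 to compound 4 (0.29 log units; within the scatter), so the same change stays within the scatter there.

On these data alone, whether an ethyl group, a methoxy group or an amine at this position would extend the step in the HepG2 assay or reverse it remains open. Compounds 1 and 2 each give only a limit of the assay, and so offer no step to set beside this one: the limit of > 100000 nM in the HepG2 assay, at which 2 of the 4 values shown sit.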